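Removing the arylazo arm from the thiazole of compound 3

The compounds below may be only part of what the source reports. "The series", "measured", "known", "first", "only" and "open" are said of these compounds alone.

Three measured compounds share one core and differ only in the group on the far aromatic ring of the azo-linked arm. In an ADME assay on a cell-free system (plasma, Rattus norvegicus) for metabolic stability (on this read-out higher numbers stand for a longer-lived compound and lower numbers for a shorter-lived compound), compound 1 `Cc1nc(N2Nc3onc(-c4ccccc4)c3C2c2ccc(Cl)cc2)sc1/N=N/c1ccc(Cl)cc1` gives 7.57 h, compound 2 `COc1ccc(/N=N/c2sc(N3Nc4onc(-c5ccccc5)c4C3c3ccc(Cl)cc3)nc2C)cc1` gives 3.9 h, and compound 3 `Cc1nc(N2Nc3onc(-c4ccccc4)c3C2c2ccc(Cl)cc2)sc1/N=N/c1ccc([N+](=O)[O-])cc1` gives 6.08 h. Every measured step stays within the scatter: a 1.9-fold lower number from compound 1 to compound 2 (0.29 log units; within the scatter), a 1.2-fold lower number from compound 1 to compound 3 (0.10 log units; within the scatter) and a 1.6-fold higher number from compound 2 to compound 3 (0.19 log units; within the scatter). Compound 3 therefore sits among numbers that cannot be told apart, with compound 1 nearest and compound 2 furthest.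

Compound 4 `Cc1csc(N2Nc3onc(-c4ccccc4)c3C2c2ccc(Cl)cc2)n1` departs from compound 3 in a different way: a hydrogen atom in place of a group of 11 heavy atoms (6 carbon, 3 nitrogen, 2 oxygen; one six-membered aromatic ring of carbon only), on an aromatic carbon. Going by the values given here, none of the measured steps touches this position; they all exchange one group for another on the distant six-membered ring and leave the azo arm in place. The data thus give no direct guide to what losing the whole arm does in this assay, and the three numbers at hand only show that the measured series clusters closely.

Among the compounds with values here, with no step bearing on the change, the expected step of a 1.1-fold lower number from compound 3 to compound 4 (0.04 log units; within the scatter) is set near zero, and the estimate for compound 4 is placed at 5.5 h with a wide range from 1.5 h to 16 h.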

Compound 4, half-life: 5.72 h
Compound 4: the middle estimate sits 1.0-fold (0.02 log units) below what was measured, within the range that was stated.
By their numbers in this assay, from the lowest: compounds 2, 4, 3 and 1 (each within the scatter of the next).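

In this assay the replacement of the whole arm by a hydrogen atom, on the aromatic carbon next to the ring sulfur, gives a 1.1-fold lower number from compound 3 to compound 4 (0.03 log units; within the scatter) and, read against the other two arms, gives a 1.5-fold higher number from compound 2 to compound 4 (0.17 log units; within the scatter) and a 1.3-fold lower number from compound 1 to compound 4 (0.12 log units; within the scatter) with all three steps inside the scatter. The earlier compounds shown here only exchanged groups on the distant six-membered ring with the azo arm in place, whereas compound 4 shows that the half-life on this read-out cannot be told apart from those of compound 1, compound 2 and compound 3 even when this position carries no arm at all, so the arm is not required for a number in this range. Nothing available explains why the number holds when so large a group leaves this position.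

The compounds shown hold only hydrogen or an arylazo arm at this carbon, so it remains open whether an amine, a carboxylic acid or a longer chain placed there would also stay within the same range. They also leave open whether the result depends on the methyl group on the neighbouring ring atom, which stays the same throughout.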